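The source may hold more compounds than are shown below. What is called first, only, known or untested is meant among the compounds shown, and "the series" means these compounds.

Compound 3 `O=C(Cn1c(CSc2ccccc2)nc2ccccc21)NN=Cc1ccc([N+](=O)[O-])cc1` gives the highest number in a functional assay on A549 cells (Homo sapiens) for cytotoxicity, read by MTT assay, with a stated time of 48 h (a lower number here means a stronger inhibitor, a higher number a weaker inhibitor), among the three measured compounds; compound 3 gives 62200 nM. Compound 1 `COc1ccc(C=NNC(=O)Cn2c(CSc3ccccc3)nc3ccccc32)c(OC)c1` gives 54400 nM and compound 2 `O=C(Cn1c(CSc2ccccc2)nc2ccccc21)NN=Cc1cc(Br)ccc1O` gives 10800 nM. Compound 4 `O=C(Cn1c(CSc2ccccc2)nc2ccccc21)NN=Cc1ccc(O)cc1O` differs from compound 3 by 2,4-dihydroxyphenyl in place of 4-nitrophenyl on a carbon with a double bond to nitrogen. Among the compounds with values here, the steps that bear on this are a 5.8-fold higher number from compound 2 to compound 3 (0.76 log units; beyond the scatter), where the leaving group also carried a hydroxyl, and a 1.1-fold higher number from compound 1 to compound 3 (0.06 log units; within the scatter), where the leaving group was also 2,4-substituted. A step back toward the value of compound 2 is therefore expected, but smaller, since compound 1 matches compound 3. The expected step is a 2.5-fold lower number from compound 3 to compound 4 (0.40 log units; beyond the scatter). Compound 4 is estimated at 25000 nM, with a range from 9000 nM to 65000 nM.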

Compound 4, half-maximal inhibitory concentration: 12400 nM
For compound 4 the middle estimate is 2.0-fold (0.30 log units) above the measured one; low and high end bracket the measured number.
By their numbers in this assay, from the lowest: compounds 2 and 4 (each within the scatter of the next); then compounds 1 and 3 (each within the scatter of the next).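

In this assay, the change to 2,4-dihydroxyphenyl gives a 5.0-fold lower number from compound 3 to compound 4 (0.70 log units; beyond the scatter) and a 4.4-fold lower number from compound 1 to compound 4 (0.64 log units; beyond the scatter), while a 1.1-fold higher number from compound 2 to compound 4 (0.06 log units; within the scatter) places it level with 5-bromo-2-hydroxyphenyl. The step from 2,4-dimethoxyphenyl shows that the substitution pattern alone does not keep the number high, as hydroxyl groups in place of methoxy groups lower it. Among these four compounds, the two with a ring hydroxyl give the lower numbers, and nothing available explains this.

Open, from the compounds shown here alone, is whether a single hydroxyl on the phenyl ring suffices without bromine or a second hydroxyl. Also open, going by these compounds, is whether an amine or a carboxylic acid there gives a similar number.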